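The source may report more compounds than this note shows. Statements on the series, on what has been measured and on what is new or still open speak of the compounds shown alone.

Three compounds built on the same core were tested in a functional assay on NCI-H23 cells (Homo sapiens) for cytotoxicity, read by sulforhodamine B assay, tested at 10 uM; on this read-out higher numbers stand for more inhibition at the one concentration tested (going by the name of the read-out) and lower numbers for less inhibition. Compound 1 `CC(=O)OC[C@H]1O[C@@H](n2cc(-c3cc(-c4ccccc4)no3)c(=O)[nH]c2=O)C[C@@H]1OC(C)=O` gives 91.4% in this assay. Compound 2 `CC(C)(C)c1ccc(-c2cc(-c3cn([C@H]4C[C@H](O)[C@@H](CO)O4)c(=O)[nH]c3=O)on2)cc1` gives 98.9% in this assay, and compound 3 `CC(=O)OC[C@H]1O[C@@H](n2cc(-c3cn(Cc4ccccc4)nn3)c(=O)[nH]c2=O)C[C@@H]1OC(C)=O` gives 98.2% in this assay. The number for compound 1 lies within the usual scatter of those for compound 3 and compound 2, so these three compounds cannot be separated on the numbers seen so far: each of them reaches a high degree of inhibition at the single concentration tested, and none can be called stronger or weaker than another.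

The compound now to be examined is compound 4 `CC(=O)OC[C@H]1O[C@@H](n2cc(-c3cc(-c4ccc(C(C)C)cc4)no3)c(=O)[nH]c2=O)C[C@@H]1OC(C)=O`. It differs from compound 1 in a single place: isopropyl in place of hydrogen on an aromatic carbon. Among the measured compounds shown here, no two measured compounds differ from each other in only one place, so there is no measured step that shows directly what this kind of change does. What the data do show is that all three measured numbers are high and close together, whatever the group on the outer ring or the state of the sugar. On that basis the step from compound 1 to compound 4 is expected to be small, a number 3.6 percentage points higher from compound 1 to compound 4 (within the scatter), and not to rise beyond the scatter. Compound 4 is therefore estimated at 95%, with a range from 85% to 100%.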

Compound 4, a percentage reported as inhibition, at one concentration (the size of the read-out at that concentration, not a potency): 108%
For compound 4 the middle estimate is 13 percentage points below the measured one; measured number above the stated range.
By their numbers in this assay, from the lowest: compounds 1, 3, 2 and 4 (each within the scatter of the next, the first and the last beyond it).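

In this assay, among the compounds shown here, putting isopropyl in place of hydrogen on the six-membered aromatic ring gives a number 16.6 percentage points higher from compound 1 to compound 4 (beyond the scatter), the only change in a single place that can be read. The earlier compounds shown here could not show this, as no two of them differed in only one place: here, one change on the phenyl group, turning it into 4-isopropylphenyl, moves the number beyond the usual scatter, and it moves it upward, so the high level of compound 1 was not yet a ceiling for this read-out. Nothing measured here explains the rise, so the step records what happened and not why it happened.

The compounds shown leave open whether this rise is particular to isopropyl, since they do not tell what a methyl group, an amine or a carboxylic acid would do at the same place on the ring. They also leave open whether the same change would give a step of similar size on a core with free hydroxyl groups on the sugar in place of the acetate esters.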